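From 4-chlorophenyl to 4-methoxyphenyl in a cytotoxicity test

A few compounds are considered here, and "the series" means these few. Any claim that something is new, unique, unknown or untested is made for them only; others in the source may bear on it.

- Compound 1 `COc1cc2ncnc(Nc3cc(O)[nH]n3)c2cc1OC` gives < 100000 nM as a limit
- Compound 2 `COc1cc2ncnc(Nc3cc(-c4ccc(F)cc4)[nH]n3)c2cc1OC` gives 69400 nM as a number
- Compound 3 `COc1cc2ncnc(Nc3cc(-c4ccc(Cl)cc4)[nH]n3)c2cc1OC` gives < 100000 nM as a limit

All three compounds were tested in a functional assay on PANC-1 cells (Homo sapiens) for cytotoxicity, read by MTT assay (on this read-out higher numbers stand for weaker inhibition and lower numbers for stronger inhibition), and share the same core. Compound 3 stands only at a limit of < 100000 nM and not at a true number. Compound 4 `COc1ccc(-c2cc(Nc3ncnc4cc(OC)c(OC)cc34)n[nH]2)cc1` differs from it by a single change, (methoxy in place of chloro on an aromatic carbon), which is methoxy in place of chloro on an aromatic carbon.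

The measured steps offer little guidance. The one nearest in kind is a step that the limit leaves unreadable from compound 2 to compound 3, and the other two are a step that the limit leaves unreadable from compound 1 to compound 2 and a step that the two limits leave unreadable from compound 1 to compound 3. None of them can be sized because of the limit of < 100000 nM in this assay, at which 2 of the 3 values shown sit. For the measured compounds named here, the only true number in the set is compound 2 at 69400 nM. No step beyond the usual scatter is therefore expected in this assay, and no direction can be named. The estimated change is a step that the limit leaves unreadable from compound 3 to compound 4. For compound 4 the expected value is 60000 nM, with an estimated range from 20000 nM to 100000 nM.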

Compound 4, half-maximal inhibitory concentration: < 100000 nM
Compound 4 gave a limit, no number; the forecaster's own chance of this, stated with the estimate: 50%; the middle value lies beyond the limit too.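

No step from compound 1, compound 2 or compound 3 to compound 4 can be read in this assay, because compound 4 also gives only a limit and not a number: the limit of < 100000 nM in this assay, at which 3 of the 4 values shown sit.

The compounds shown leave open whether methoxy in place of chloro changes the result in this assay at all, since true numbers for compound 3 and compound 4 are lacking.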